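Compound 2 and its formyl counterpart, compound 3

A few compounds are considered here, and "the series" means these few. Any claim that something is new, unique, unknown or untested is made for them only; others in the source may bear on it.

Measured so far in a functional assay on MCF7 cells (Homo sapiens) for antiproliferative activity, read by MTT assay, with a stated time of 72 h; a higher number here means a weaker inhibitor, a lower number a stronger inhibitor
compound 1 `C=C1CC[C@H]2O[C@@]2(C)[C@H](OC(=O)C=C(C)C)/C=C/[C@@](C)(CCC=C(C)C)C[C@H]1O` gives > 20000 nM
compound 2 `CC(C)=CCC[C@]1(C)/C=C/[C@@H](OC(=O)C=C(C)C)[C@]2(C)O[C@@H]2CC/C(CO)=C\C1` gives 15000 nM

The entry for compound 1 at > 20000 nM is a limit of the assay and not a number. Going by the values given here, compound 2 at 15000 nM holds the only true number in this assay and so offers the single firm reference point. Compound 3 `CC(C)=CCC[C@]1(C)/C=C/[C@@H](OC(=O)C=C(C)C)[C@]2(C)O[C@@H]2CC/C(C=O)=C\C1` has not yet been measured. Its change from compound 2 is formyl in place of hydroxymethyl on a double-bonded ring carbon with formyl in place of hydroxymethyl on a double-bonded ring carbon. Among the compounds with values here, no step between measured compounds is available to size this swap. A moderate move toward stronger inhibition is expected, and the estimated step of a 3.0-fold lower number from compound 2 to compound 3 (0.48 log units; beyond the scatter) is only modestly beyond the scatter. For compound 3 the estimate is 5000 nM with an expected range from 1500 nM to 20000 nM in this assay when it is measured.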

Compound 3, half-maximal inhibitory concentration: 12000 nM
Compound 3: the middle estimate sits 2.4-fold (0.38 log units) below what was measured; low and high end bracket the measured number.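

In this assay the swap of formyl in place of hydroxymethyl on a double-bonded ring carbon comes to a 1.3-fold lower number from compound 2 to compound 3 (0.10 log units; within the scatter). Going by these compounds alone, the two compounds cannot be told apart here, so at this position of the ring a hydroxymethyl group with its hydrogen-bond donor and a formyl group with none read alike in this assay, something the earlier compounds could not show. Compound 1 stands at a limit of the assay and not a number: the limit of > 20000 nM in this assay, at which 1 of the 3 values shown sits.

The compounds shown leave open whether a carboxylic acid, an aminomethyl group or a plain methyl group on this ring carbon would separate from compound 2 and compound 3. They also leave open whether formyl and hydroxymethyl would still read alike with the ((2-methylprop-1-en-1-yl)carbonyl)oxy group replaced by a simple acetate.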